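A few compounds are considered here, and "the series" means these few. Any claim that something is new, unique, unknown or untested is made for them only; others in the source may bear on it.

Three closely related compounds have been tested in an ADME assay on HEK293 cells (Homo sapiens) for cytotoxicity, read by CellTiter-Glo and resazurin assay, with a stated time of 72 h; on this read-out higher numbers stand for an effect only at larger amounts of compound and lower numbers for an effect already at smaller amounts. Compound 1 `CCCNCc1cccc(OCCCCCC(=O)OCC)c1` carries a (propylamino)methyl group on its aromatic ring. In this assay compound 1 gives > 26000 nM, which is a limit of the assay and not a number. Compound 2 `CCCNCc1ccc(OCCCCCC(=O)OCC)cc1` is built from the same atoms joined differently; the difference between the two cores is not broken down here. In this assay compound 2 gives > 26000 nM, again a limit rather than a number. Compound 3 `CCOC(=O)CCCCCOc1cccc(C=O)c1` differs from compound 1 by formyl in place of (propylamino)methyl on an aromatic carbon. In this assay compound 3 gives > 26000 nM, once more a limit. The step that the two limits leave unreadable from compound 1 to compound 3 therefore cannot be read, since both of its ends sit at the limit of > 26000 nM in this assay, at which 3 of the 3 values shown sit.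

Compound 4 `CCOC(=O)CCCCCOc1ccc(C=O)cc1` has not yet been measured. It differs from compound 2 by formyl in place of (propylamino)methyl on an aromatic carbon. Among the measured compounds shown here, this is the same kind of change as the one from compound 1 to compound 3, but not the same: there the formyl group enters meta to a large group, here para to a large group. The step that the limit leaves unreadable from compound 2 to compound 4 is expected to be small. That expectation rests on compound 1 and compound 3, which both sit at the limit of > 26000 nM in this assay, at which 3 of the 3 values shown sit, so that the step that the two limits leave unreadable from compound 1 to compound 3 showed no readable shift. Compound 4 is accordingly expected to give about 40000 nM, most likely reported only as a limit of the assay.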

Compound 4, half-maximal effective concentration: > 26000 nM
Compound 4 was reported as a limit; the forecaster's own chance of this, stated with the estimate: 85%; the middle value does not contradict the limit.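

No new step can be read from compound 2 to compound 4, since each of the two is reported only as a limit of the assay and not as a number: the limit of > 26000 nM in this assay, at which 4 of the 4 values shown sit.

The compounds shown leave open what actual number any of them would give in this assay, and so whether formyl in place of (propylamino)methyl changes the read-out at all.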